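A few compounds are considered here, and "the series" means these few. Any claim that something is new, unique, unknown or untested is made for them only; others in the source may bear on it.

Measured compounds:
compound 1, `Cc1cn2c(-c3cn[nH]c3)cnc2c(Nc2cc(Cn3cccc3)ns2)n1`: "not determined" (no result reported)
compound 2, `Cc1cn2c(-c3cn[nH]c3)cnc2c(Nc2cc(Cn3cccc(C)c3=O)ns2)n1`: "not determined" (no result reported)
compound 3, `Cc1cn2c(-c3cn[nH]c3)cnc2c(Nc2cc(Cc3nccs3)ns2)n1`: 1540 ng.h/mL

Three compounds sharing one core were followed in an ADME assay on the whole organism for pharmacokinetics, with Rattus norvegicus as the target, with a stated time of 6 h, at a dose of 10 mg/kg by the oral route; a higher number here means more compound in the circulation at the dose given, a lower number less compound in the circulation. Compound 1 has no single number there: its entry reads "not determined" (no result reported). Compound 2 is in the same position, with "not determined" (no result reported) in this assay . Only compound 3 carries a number, giving 1540 ng.h/mL in this assay . So compound 1 cannot be placed on the scale at all; the one anchor is compound 3.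

Compound 4, `Cc1cn2c(-c3cn[nH]c3)cnc2c(Nc2cc(Cc3ccc(F)cn3)ns2)n1`, has not yet been run in this assay . It differs from compound 1 in one place: 5-fluoropyridin-2-yl in place of 1H-pyrrol-1-yl on a saturated chain carbon bound to an aromatic carbon. Among the compounds with values here, since compound 1 has no number, no step can be drawn from compound 1 to compound 4, and nothing in the data shows which way such a step would go or whether it would exceed the usual scatter. Within the data shown here, the only guide is compound 3, whose value in this assay is 1540 ng.h/mL. On that basis compound 4 is expected to reach about 1000 ng.h/mL, within a range from 250 ng.h/mL to 4000 ng.h/mL.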

Compound 4, area under the concentration-time curve: 2240 ng.h/mL
Estimate against measurement, compound 4: 2.2-fold (0.35 log units) below, and the stated range covers the measured number.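

In this assay, replacing 1,3-thiazol-2-yl with 5-fluoropyridin-2-yl on a saturated chain carbon bound to an aromatic carbon gives a 1.5-fold higher number from compound 3 to compound 4 (0.16 log units; within the scatter), so the two compounds cannot be told apart here. This position therefore carries either a five-membered or a six-membered aromatic ring without a clear shift in the amount of compound reaching the circulation, while steps from compound 1 or compound 2 cannot be read because neither has a number. Nothing available bears on what lies behind this result.

Within the data shown here, only two aromatic rings have numbers at this position, so it remains open whether a plain pyridin-2-yl without the fluorine, a saturated amine such as morpholine, or a longer chain would keep the value in the same range. A single pair also cannot show how this change would behave on a different core.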